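Ring-nitrogen aryl swap: from compound 1 to compound 4

A few compounds are considered here, and "the series" means these few. Any claim that something is new, unique, unknown or untested is made for them only; others in the source may bear on it.

Of the compounds shown here, three have been measured in an assay on isolated protein for inhibition of protein kinase C zeta type (Homo sapiens), with a stated time of 4 min, tested at 62.5 uM; on this read-out higher numbers stand for more inhibition at the one concentration tested (going by the name of the read-out) and lower numbers for less inhibition. Compound 1 `CC(C)(C)C1=NN(c2ccc(F)cc2)C(c2ccc(O)cc2)C1` gives 95.5% in this assay, the highest of the three numbers; its nearest neighbour, compound 3 `CC(C)(C)C1=NN(c2ccccc2F)C(c2ccc(O)cc2)C1`, gives 57.6%, and compound 2 `CC(C)(C)C1=NN(c2ccccc2Cl)C(c2ccc(O)cc2)C1` gives 57.1%, both steps from compound 1 being beyond the scatter. Compound 4 `CC(C)(C)C1=NN(c2ccc(Cl)cc2Cl)C(c2ccc(O)cc2)C1` has not been measured yet. It differs from compound 1 in one place: 2,4-dichlorophenyl in place of 4-fluorophenyl on an amine nitrogen in a ring.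

For the measured compounds named here, two measured steps bear on this change, since each also replaces the 4-fluorophenyl group on the ring nitrogen with a differently substituted phenyl ring. The step of a number 38.4 percentage points lower from compound 1 to compound 2 (beyond the scatter) and the step of a number 37.9 percentage points lower from compound 1 to compound 3 (beyond the scatter) were both large drops, and the step of a number 0.5 percentage points higher from compound 2 to compound 3 (within the scatter) shows that swapping chloro for fluoro on that ring made no difference beyond the scatter. Compound 4 carries a chloro group at the same position as compound 2 does, together with a second chloro group, so a loss of similar size is expected: the step of a number 37.5 percentage points lower from compound 1 to compound 4 (beyond the scatter) is the estimated outcome. For compound 4 the expected value in this assay is therefore 58%, within a range from 35% to 82%.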

Compound 4, a percentage reported as inhibition, at one concentration (the size of the read-out at that concentration, not a potency): 71%
Compound 4: middle estimate off by 13 percentage points, on the low side, and the stated range covers the measured number.
By their numbers in this assay, from the lowest: compounds 2 and 3 (each within the scatter of the next); then compound 4; then compound 1.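

Until now, the two groups that replaced 4-fluorophenyl on this ring nitrogen, 2-chlorophenyl and 2-fluorophenyl, could not be told apart, but compound 4 shows that the position responds to more than that single swap: in this assay, adding a second chloro to the ring gives a number 13.9 percentage points higher from compound 2 to compound 4 (beyond the scatter), and the 2,4-dichlorophenyl group also stands above the 2-fluorophenyl group, with a number 13.4 percentage points higher from compound 3 to compound 4 (beyond the scatter). For the compounds shown here, the recovery is only partial, with a number 24.5 percentage points lower from compound 1 to compound 4 (beyond the scatter), yet in these four compounds the two groups with a halogen numbered 4 in their names, 4-fluorophenyl and 2,4-dichlorophenyl, both stand above the two groups without one, and no compound here goes against that. No measurement is available to explain these differences.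

The compounds shown leave open how a plain phenyl or a 4-chlorophenyl group would behave on this nitrogen, and either would help separate the contribution of each halogen. From the compounds shown here alone, it also remains open whether something other than a halogen, such as a 4-methoxyphenyl group, would give a similarly high number.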